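Swapping 3,4-dichlorophenyl for 4-bromophenyl in compound 3

The source may report more compounds than this note shows. Statements on the series, on what has been measured and on what is new or still open speak of the compounds shown alone.

compound 1 `O=S(=O)(/C=C/c1ccc(F)cc1)Cc1ccc(Nc2ncnc3ccccc23)cc1` gives 13000 nM
compound 2 `O=S(=O)(/C=C/c1ccc(Cl)c(Cl)c1)Cc1ccc(Nc2ncnc3ccccc23)cc1` gives 32000 nM

In a functional assay on NCI-H520 cells (Homo sapiens) (on this read-out higher numbers stand for weaker inhibition of growth and lower numbers for stronger inhibition of growth), compound 2 stands at 32000 nM as the higher of the two numbers, which makes it the weaker growth inhibitor of the pair. Compound 3 `O=S(=O)(/C=C/c1ccc(Br)cc1)Cc1ccc(Nc2ncnc3ccccc23)cc1` is still unmeasured and differs from compound 2 in one place (4-bromophenyl in place of 3,4-dichlorophenyl on a double-bonded chain carbon bound to a double-bonded chain carbon). Among the measured compounds shown here, only one measured step bears on this change (a 2.5-fold higher number from compound 1 to compound 2 (0.39 log units; beyond the scatter)), a modest one that came with 3,4-dichlorophenyl in place of 4-fluorophenyl at that same place. For the measured compounds named here, the 4-bromophenyl of compound 3 looks more like the 4-fluorophenyl of compound 1 (13000 nM) than like 3,4-dichlorophenyl, although no measured compound carries bromine. In this assay a modest step toward a lower number is therefore expected (a 2.1-fold lower number from compound 2 to compound 3 (0.33 log units; beyond the scatter)). For compound 3 the estimate is 15000 nM (expected range 7000 nM to 32000 nM).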

Compound 3, concentration for 50% growth inhibition: > 100000 nM
Compound 3: no number, only a limit; the forecaster's own chance of this, stated with the estimate: 5%; middle value at least 6.6-fold (0.82 log units) from the limit.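

In this assay compound 3 reads > 100000 nM, which is a limit of the assay and not a number: the limit of > 100000 nM in this assay, at which 1 of the 3 values shown sits. Even so, the steps can be read as minimum sizes: exchanging one halogen on an aromatic carbon gives an at least 7.6-fold higher number from compound 1 to compound 3 (0.88 log units; beyond the scatter), while 4-bromophenyl in place of 3,4-dichlorophenyl gives an at least 3.1-fold higher number from compound 2 to compound 3 (0.49 log units; beyond the scatter). The earlier compounds shown here showed only a modest step at this place, whereas these steps show that the identity of the halogen can matter more than the number of halogens, since compound 3, with one halogen, gives a higher number than compound 2, with two.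

From the compounds shown here alone, how far the true value of compound 3 lies past its limit remains open. Also open, going by these compounds, is whether 4-chlorophenyl, unsubstituted phenyl or 4-methoxyphenyl would fall closer to compound 1 or to compound 3.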